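Losing the 3,4-dihydroxyphenyl group of compound 3

This account rests on a few compounds, and the source may have more. Where it says the series, first, only, none or still open, it means among the compounds named here.

Compound 1 `Cc1ccc(/C=C2/S/C(=N/c3ccccc3)N(Cc3ccncc3)C2=O)cc1`: 36900 nM
Compound 2 `COc1ccc(/C=C2/S/C(=N/c3ccccc3)N(Cc3ccncc3)C2=O)cc1`: 31500 nM
Compound 3 `O=C1/C(=C\c2ccc(O)c(O)c2)S/C(=N/c2ccccc2)N1Cc1ccncc1`: 12400 nM

All three compounds were tested in a functional assay on MCF7 cells (Homo sapiens) for cytotoxicity, read by MTT assay, with a stated time of 48 h; on this read-out lower numbers stand for stronger inhibition and higher numbers for weaker inhibition. Compound 3 has the lowest number of the three, and both steps that lead to it lie beyond the scatter: a 3.0-fold lower number from compound 1 to compound 3 (0.47 log units; beyond the scatter) and a 2.5-fold lower number from compound 2 to compound 3 (0.40 log units; beyond the scatter). Both are modest. The remaining step, a 1.2-fold lower number from compound 1 to compound 2 (0.07 log units; within the scatter), lies within the scatter, so exchanging methyl for methoxy on the aromatic ring shows no measurable change in this set.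

Compound 4 `COc1ccc(OC)c(/C=C2/S/C(=N/c3ccccc3)N(Cc3ccncc3)C2=O)c1` keeps the shared core and changes only on a double-bonded chain carbon bound to a double-bonded ring carbon: 2,5-dimethoxyphenyl in place of 3,4-dihydroxyphenyl on a double-bonded chain carbon bound to a double-bonded ring carbon. Within the data shown here, no measured compound carries the 2,5-dimethoxyphenyl group, so any forecast has to lean on its nearest relatives. The closest is compound 2, with its 4-methoxyphenyl group, at 31500 nM. Read in reverse, the step of a 2.5-fold lower number from compound 2 to compound 3 (0.40 log units; beyond the scatter) suggests that leaving the 3,4-dihydroxyphenyl group gives back a modest rise in this assay. The data cannot show what the different placement of the methoxy groups adds, so the range stays wide.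

The estimated change is a 2.3-fold higher number from compound 3 to compound 4 (0.35 log units; beyond the scatter), a modest step toward a higher number. The expected value for compound 4 is 28000 nM, with an estimated range from 12000 nM to 65000 nM.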

Compound 4, half-maximal inhibitory concentration: 37000 nM
Estimate against measurement, compound 4: 1.3-fold (0.12 log units) below; the measured number falls inside the stated range.
By their numbers in this assay, from the lowest: compound 3; then compounds 2, 1 and 4 (each within the scatter of the next).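

With the 2,5-dimethoxyphenyl group on the double-bonded chain carbon bound to a double-bonded ring carbon, this assay gives a 3.0-fold higher number from compound 3 to compound 4 (0.47 log units; beyond the scatter), which shows that two oxygen atoms on the aromatic ring do not by themselves keep the lower number of compound 3, since both groups carry two. The other two steps, a 1.2-fold higher number from compound 2 to compound 4 (0.07 log units; within the scatter) and a 1.0-fold higher number from compound 1 to compound 4 (0.00 log units; within the scatter), lie within the scatter, so the 2,5-dimethoxyphenyl group shows no measurable change from either the 4-methoxyphenyl or the 4-methylphenyl group. Compounds 1, 2 and 4 thus stand together at this position, and among the four compounds only the 3,4-dihydroxyphenyl group of compound 3 gives a number set apart from the rest, a modest separation. No supporting measurement is available to explain this difference.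

The compounds shown leave open whether the lower number follows the hydroxyl groups themselves or their placement on the ring, a question that a 3,4-dimethoxyphenyl or a 4-hydroxyphenyl group at this place could help to separate. They also leave open how an aromatic ring carrying an amine or a carboxylic acid would read here.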